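Exposure after oral cassette dosing: compound 2 to compound 4

A few compounds are considered here, and "the series" means these few. Any claim that something is new, unique, unknown or untested is made for them only; others in the source may bear on it.

The series shares one core bearing a substituted nitrogen and a biaryl arm. Compound 1 `C[C@H](c1ccc(-c2cc(F)ccc2-c2nc(=O)o[nH]2)cc1)N(CC1CC1)c1nc2c(C(=O)O)cccc2o1` gives 4410 ng.h/mL in an ADME assay on the whole organism (Macaca fascicularis) for pharmacokinetics, read by LC-MS, using cassette dosing, at a dose of 1 mg/kg by the oral route; a lower number here means less compound in the circulation, a higher number more compound in the circulation at the dose given. Within the data shown here, compound 3 `CCCCN(c1nc2c(C(=O)O)cccc2o1)[C@H](C)c1ccc(-c2cc(F)ccc2-c2nc(=O)o[nH]2)cc1` gives 1630 ng.h/mL in this assay, and the step of a 2.7-fold lower number from compound 1 to compound 3 (0.43 log units; beyond the scatter) is the only single-point change measured. Compound 2 `CCCCN(c1nc2c(C(=O)N(C)C)cccc2o1)[C@H](C)c1ccc(-c2ccccc2-c2nnn[nH]2)cc1` gives 104 ng.h/mL, the lowest of the three numbers, well apart from compound 3 and further still from compound 1; it differs from both in more than one place, so those gaps show only the two values, not a single cause.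

Compound 4 `CCCCN(c1nc2c(-c3ccccn3)cccc2o1)[C@H](C)c1ccc(-c2ccccc2-c2nnn[nH]2)cc1` is unmeasured. It differs from compound 2 by pyridin-2-yl in place of dimethylcarbamoyl on an aromatic carbon. Among the measured compounds shown here, no measured step touches this position; the step from compound 1 to compound 3 sits on the chain carbon at the nitrogen and does not bear on an exchange at the aromatic carbon. With nothing to direct the expectation, a step near the scatter in either direction is expected, a 1.4-fold higher number from compound 2 to compound 4 (0.16 log units; within the scatter). Compound 4 is therefore estimated at 150 ng.h/mL, with a range from 40 ng.h/mL to 600 ng.h/mL.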

Compound 4, area under the concentration-time curve: 248 ng.h/mL
The estimate for compound 4 lay 1.7-fold (0.22 log units) below the measured number; low and high end bracket the measured number.
By their numbers in this assay, from the lowest: compound 2; then compound 4; then compound 3; then compound 1.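

In this assay, this aromatic carbon of the shared core now has its first reading from a change in one place: a 2.4-fold higher number from compound 2 to compound 4 (0.38 log units; beyond the scatter), with the rest of the molecule held constant. The position therefore responds to this exchange, in which pyridin-2-yl, with its six-membered aromatic ring, replaces dimethylcarbamoyl, which has no ring, while the hydrogen-bond donor and acceptor counts stay the same. Nothing available gives a reason for the rise.

On these data alone, a single exchange cannot separate the entry of the ring from the loss of the carbonyl, so it remains open how a nitrile, an amine or a phenyl ring would behave at this carbon. Compound 1 and compound 3 carry a carboxylic acid there, but they differ from compound 2 and compound 4 in more than one place, so those pairs cannot be read for this position.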